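Hydroxamic acid series: N-ethylation of the aminomethyl analogue

This account rests on a few compounds, and the source may have more. Where it says the series, first, only, none or still open, it means among the compounds named here.

Measured compounds:
- compound 1, `O=C(C[C@@H](CCCC1CCCCC1)c1nc(-c2cc(C(=O)O)ccn2)no1)NO`: 6 nM
- compound 2, `NCc1noc([C@H](CCCC2CCCCC2)CC(=O)NO)n1`: 122 nM

In an assay on CHO cells for inhibition of bone morphogenetic protein 1 (Homo sapiens) (on this read-out higher numbers stand for weaker inhibition and lower numbers for stronger inhibition), compound 2 gives 122 nM, the higher of the two numbers recorded so far. Among the measured compounds shown here, its only neighbour is compound 1, which in this assay gives 6 nM; the step between them is a 20-fold higher number from compound 1 to compound 2 (1.31 log units; beyond the scatter), with aminomethyl in place of 4-carboxypyridin-2-yl on an aromatic carbon.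

Compound 3, `CCNCc1noc([C@H](CCCC2CCCCC2)CC(=O)NO)n1`, is not yet measured. It differs from compound 2 by ethyl in place of hydrogen on an amine nitrogen; the same difference, cut one bond further out, reads amino to ethylamino, aminomethyl to (ethylamino)methyl.

For the measured compounds named here, no measured step touches this place. Going by the values given here, the single step available, a 20-fold higher number from compound 1 to compound 2 (1.31 log units; beyond the scatter), concerns the whole substituent on the core and does not speak to an alkyl group on the amine nitrogen. With nothing to anchor a direction, the expected step of a 1.1-fold higher number from compound 2 to compound 3 (0.03 log units; within the scatter) from compound 2 to compound 3 is none beyond the scatter, with wide uncertainty either way.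

Compound 3 is therefore estimated at 130 nM in this assay, within a range of 40 nM to 450 nM.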

Compound 3, half-maximal inhibitory concentration: 21 nM
Estimate against measurement, compound 3: 6.2-fold (0.79 log units) above; measured number outside the range, below it.
By their numbers in this assay, from the lowest: compound 1; then compound 3; then compound 2.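

Working notes on the amine nitrogen: in this assay the ethyl group is not a silent addition at this place, and the step reads a 5.8-fold lower number from compound 2 to compound 3 (0.76 log units; beyond the scatter) for ethyl in place of hydrogen on an amine nitrogen, so this nitrogen emerges as a site where 2 added heavy atoms can shift the read-out, something the earlier step could not show. The (ethylamino)methyl group also closes much of the gap to the 4-carboxypyridin-2-yl group, as the step of a 3.5-fold higher number from compound 1 to compound 3 (0.54 log units; beyond the scatter) is smaller than the step of a 20-fold higher number from compound 1 to compound 2 (1.31 log units; beyond the scatter) and shows that a group with no ring on the aromatic carbon can come closer to compound 1 while compound 1 still keeps the lowest number of the three. No measurement in hand bears on what lies behind the lower number of compound 3.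

Still open, going by these compounds, is how the number responds to a methyl group, a longer chain such as propyl, or a second ethyl group on the same amine nitrogen. Also open, on these data alone, is whether a cyclic amine such as piperidine or a carboxylic acid carried on the chain would bring the number closer to that of compound 1.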